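Oxolane to Oxetane on the Aromatic Nitrogen: Clearance Outlook

The compounds below may be only part of what the source reports. "The series", "measured", "known", "first", "only" and "open" are said of these compounds alone.

Compound 1 `Cc1nn(CC2(O)COC2)cc1Nc1nc(N)c2c(C#N)c(N3CCC[C@H]3C)n(C)c2n1`: 76.7 mL/min/kg
Compound 2 `Cc1c(Nc2nc(N)c3c(C#N)c(N4CCC[C@H]4C)n(C)c3n2)cnn1CC(C)(C)O`: 30 mL/min/kg
Compound 3 `Cc1c(Nc2nc(N)c3c(C#N)c(N4CCC[C@H]4C)n(C)c3n2)cnn1[C@@H]1CCOC1`: 28.3 mL/min/kg

Three compounds built on one shared core have been run in an ADME assay on microsomes from liver (Homo sapiens) for pharmacokinetics; on this read-out lower numbers stand for slow clearance and higher numbers for fast clearance. Compound 3 gives 28.3 mL/min/kg, the lowest of the three numbers. Compound 2 sits nearest to it, within the scatter, while compound 1 lies furthest, beyond the scatter in the direction of faster clearance. For the measured compounds named here, the single step along one structural change is a 1.1-fold lower number from compound 2 to compound 3 (0.03 log units; within the scatter), and it falls within the scatter.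

Compound 4 `Cc1c(Nc2nc(N)c3c(C#N)c(N4CCC[C@H]4C)n(C)c3n2)cnn1C1COC1` has not yet been measured in this assay. Against compound 3 it shows (oxetan-3-yl in place of oxolan-3-yl on an aromatic nitrogen). Going by the values given here, the only measured step bearing on a change at this aromatic nitrogen is the one from compound 2 to compound 3, and that step was within the scatter. Among the compounds with values here, no measured pair exchanges these two rings directly, and compound 1, which carries a substituted oxetan-3-yl on an aromatic nitrogen, differs from compound 3 in more than one place and so gives no clean step. On this basis only a small step, a 1.1-fold higher number from compound 3 to compound 4 (0.03 log units; within the scatter), is expected, with no direction claimed beyond the scatter. Compound 4 is therefore estimated at 30 mL/min/kg, with a range from 15 mL/min/kg to 60 mL/min/kg.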

Compound 4, clearance: 14.3 mL/min/kg
Compound 4: the middle estimate sits 2.1-fold (0.32 log units) above what was measured; measured number below the stated range.
By their numbers in this assay, from the lowest: compounds 4, 3 and 2 (each within the scatter of the next, the first and the last beyond it); then compound 1.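

In this assay, replacing oxolan-3-yl with oxetan-3-yl on the aromatic nitrogen gives a 2.0-fold lower number from compound 3 to compound 4 (0.30 log units; within the scatter), so this exchange of a five-membered ring for a four-membered one, which also removes the defined stereocentre, does not separate the two compounds beyond the scatter. For the compounds shown here, replacing 2-hydroxy-2-methylpropyl with oxetan-3-yl gives a 2.1-fold lower number from compound 2 to compound 4 (0.32 log units; beyond the scatter), the only step at this position that lies beyond the scatter, whereas a 1.1-fold lower number from compound 2 to compound 3 (0.03 log units; within the scatter) did not show that the number responds to a change here. The position can therefore shift the clearance number modestly across these three groups, but no supporting measurement is available to explain that shift.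

As far as these compounds go, whether an amine, a carboxylic acid or a longer chain on this aromatic nitrogen would take the number further from that of compound 4 remains open. Compounds 2, 3 and 4 also keep the methyl group and the rest of the shared core fixed, so they leave open how the oxetan-3-yl step would read with a different group at those places.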